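Solubility notes: furanylmethyl to hydroxymethoxybenzyl on the phenoxy series

The source may hold more compounds than are shown below. What is called first, only, known or untested is meant among the compounds shown, and "the series" means these compounds.

Compound 3 `COc1cccc(Oc2ccc3c(NCCCNCc4ccco4)ccnc3c2)c1` is the least soluble of the three measured compounds: in a physicochemical assay for solubility, with a stated time of 18 h, at pH 7.4 (on this read-out lower numbers stand for lower solubility and higher numbers for higher solubility), compound 3 gives 14500 nM, a gap beyond the scatter to both others. Compound 1 `COc1cccc(CNCCCNc2ccnc3cc(-c4ccc(F)cc4)ccc23)c1O` gives 32000 nM in this assay, and compound 2 `COc1cccc(CNCCCNc2ccnc3cc(-c4ccc(C(C)(C)C)cc4)ccc23)c1O` gives 32000 nM. Going by the values given here, the only single-point step measured, no change at the digits printed from compound 1 to compound 2 (within the scatter), sits on the aryl ring of the shared core and does not touch the chain end that changes here.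

Compound 4 `COc1cccc(Oc2ccc3c(NCCCNCc4cccc(OC)c4O)ccnc3c2)c1` keeps the core of compound 3 and carries 2-hydroxy-3-methoxyphenyl in place of furan-2-yl on a saturated chain carbon bound to an amine nitrogen. Among the compounds with values here, no measured step covers this swap. What can be read is that compound 1 and compound 2, which both carry the 2-hydroxy-3-methoxybenzyl amine on a different core, sit somewhat higher than compound 3. Compound 4 is therefore expected to move modestly upward, a 1.5-fold higher number from compound 3 to compound 4 (0.18 log units; within the scatter), with the direction uncertain and much of the range within the scatter. The estimate for compound 4 in this assay is 22000 nM, between 9000 nM and 55000 nM.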

Compound 4, solubility: 14500 nM
Compound 4: middle estimate off by 1.5-fold (0.18 log units), on the high side; low and high end bracket the measured number.
By their numbers in this assay, from the lowest: compounds 3 and 4 (each within the scatter of the next); then compounds 1 and 2 (each within the scatter of the next).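

In the solubility read-out, the change on a saturated chain carbon bound to an amine nitrogen leaves the number flat (no change at the digits printed from compound 3 to compound 4 (within the scatter)), so furan-2-yl and 2-hydroxy-3-methoxyphenyl are not told apart at this position on this core in this assay. With the chain end now matched, the remaining gaps belong to the change on an aromatic carbon, with 3-methoxyphenoxy entering in both steps (a 2.2-fold lower number from compound 1 to compound 4 (0.34 log units; beyond the scatter); a 2.2-fold lower number from compound 2 to compound 4 (0.34 log units; beyond the scatter)). Nothing available bears on the reason for these numbers.

As far as these compounds go, whether a carboxylic acid or a morpholine at this chain end would move the number remains open. Also open is whether the flat result at this position holds on the core of compound 1, where no furan-2-yl partner is shown.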